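Brominated butenolide series: halogen swap at the exocyclic carbon

The source may hold more compounds than are shown below. What is called first, only, known or untested is meant among the compounds shown, and "the series" means these compounds.

Of the compounds shown here, three of the shared core have a number so far. Compound 1, `CCC[C@@H](OC(C)=O)C1=C(Br)/C(=C/Br)OC1=O`, gives 1 ug/mL in a functional assay on KB cells (Homo sapiens) for cytotoxicity; on this read-out higher numbers stand for an effect only at larger amounts of compound and lower numbers for an effect already at smaller amounts. Compound 2, `CCC[C@@H](O)C1=C(Br)/C(=C/I)OC1=O`, gives 0.3 ug/mL in this assay, the lowest of the three and beyond the scatter from both others; it is the most active compound here. Compound 3, `CCC[C@@H](OC(C)=O)C1=C(Br)[C@](OC)(C(Br)Br)OC1=O`, gives 6.1 ug/mL in this assay, the highest of the set. Compound 1 and compound 3 differ in more than one place, so their gap is read only as a pair of values, not as a single step.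

Compound 4, `CCC[C@@H](O)C1=C(Br)/C(=C/Cl)OC1=O`, has not been measured in this assay. It differs from compound 2 in one place: chloro in place of iodo on a double-bonded chain carbon bound to a double-bonded ring carbon. Within the data shown here, no single-change step between measured compounds covers a halogen exchange at this chain carbon, so the size of the step is not known from the data. The expectation is a small move toward a higher number, likely within or just beyond the scatter, since compound 2 stands at 0.3 ug/mL and every other halogen pattern in the set gives a higher value. The estimated step is a 2.0-fold higher number from compound 2 to compound 4 (0.30 log units; within the scatter). Compound 4 is expected to give 0.6 ug/mL in this assay, with a range from 0.15 ug/mL to 2.5 ug/mL.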

Compound 4, concentration for half-maximal effect: 1.4 ug/mL
The estimate for compound 4 lay 2.3-fold (0.37 log units) below the measured number, within the range that was stated.
By their numbers in this assay, from the lowest: compound 2; then compounds 1 and 4 (each within the scatter of the next); then compound 3.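

The halogen on the double-bonded chain carbon bound to a double-bonded ring carbon is not a silent feature: in this assay, chloro in place of iodo gives a 4.7-fold higher number from compound 2 to compound 4 (0.67 log units; beyond the scatter). Among these compounds, this is the first single-change step, and so the first reading of this halogen with the rest of the molecule held constant, including the free hydroxyl on the chain; the earlier gaps among compounds 1, 2 and 3 each involve more than one change and could not isolate it. The data establish the direction and size of this one exchange, but no accompanying measurement bears on what lies behind it.

Two points on this exchange cannot show a trend across the halogens, and a matched bromo compound carrying the free hydroxyl would be needed to place bromo on the same scale. Going by these compounds, it also remains open whether the step carries over to compounds with the acetate on the chain, and how fluoro or a nitrile on this chain carbon would stand against iodo and chloro.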